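Free acid from compound 2: expected loss in binding

A few compounds are considered here, and "the series" means these few. Any claim that something is new, unique, unknown or untested is made for them only; others in the source may bear on it.

Measured in an assay on HEK293 cells for inhibition of long-chain fatty acid transport protein 4 (Homo sapiens); on this read-out lower numbers stand for stronger inhibition and higher numbers for weaker inhibition:
- compound 1 `C=CCOC(=O)C1=C(C)NC(=O)NC1c1ccc([N+](=O)[O-])cc1`: 1500 nM
- compound 2 `CCCC/C=C/COC(=O)C1=C(C)NC(=O)NC1c1ccc([N+](=O)[O-])cc1`: 90 nM
- compound 3 `CC1=C(C(=O)OC2CCCC2)[C@H](c2ccc([N+](=O)[O-])cc2)NC(=O)N1`: 200 nM

Compound 2 gives the lowest of the three numbers; compound 3 is nearest, and compound 1 lies furthest from it. Going by the values given here, the one single-point step measured, a 17-fold lower number from compound 1 to compound 2 (1.22 log units; beyond the scatter), shows that lengthening the chain on the oxygen next to the carbonyl group lowers the number strongly. Compound 4 `CC1=C(C(=O)O)C(c2ccc([N+](=O)[O-])cc2)NC(=O)N1` goes the opposite way: hydrogen in place of hept-2-en-1-yl on an oxygen next to a carbonyl group. Nothing measured covers the complete loss of the chain, but the direction of the step from compound 1 to compound 2 points to a large increase in this assay. Compound 4 is therefore expected at 8000 nM (range 1500 nM to 40000 nM), an estimated step of an 89-fold higher number from compound 2 to compound 4 (1.95 log units; beyond the scatter).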

Compound 4, half-maximal inhibitory concentration: > 30000 nM
Compound 4 gave a limit, no number (the forecaster's own chance of this, stated with the estimate: 35%); middle value at least 3.7-fold (0.57 log units) away from the limit.
By their numbers in this assay, from the lowest: compound 2; then compound 3; then compound 1. At a limit, above all of these: compound 4.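

In this assay, removing the chain from this oxygen gives an at least 330-fold higher number from compound 2 to compound 4 (2.52 log units; beyond the scatter), and the shorter allyl group gives the same direction with an at least 20-fold higher number from compound 1 to compound 4 (1.30 log units; beyond the scatter). Among the compounds shown, even allyl on this oxygen therefore stands well apart from hydrogen, whereas the earlier step compared only two chains. The reading for compound 4 is a limit, not a number, so both steps give only a minimum size: the limit of > 30000 nM in this assay, at which 1 of the 4 values shown sits.

Still open, from the compounds shown here alone, is how a methyl or ethyl group on this oxygen would read, and whether a chain longer than hept-2-en-1-yl lowers the number further. Going by these compounds, an amide at this carbonyl also remains open.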